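The source may report more compounds than this note shows. Statements on the series, on what has been measured and on what is new or still open speak of the compounds shown alone.

Compound 1 `C=C(C)CCC[C@]1(C)C2=CCC[C@](C)(CC(=O)c3ccoc3)[C@H]2CC[C@H]1C` is reported in a functional assay on A549 cells (Homo sapiens) for antiproliferative activity, read by XTT assay, with a stated time of 72 h (a higher number here means a weaker inhibitor, a lower number a stronger inhibitor), only as a limit, > 100000 nM. Going by the values given here, compound 2 `C=C(C)CCC[C@]1(C)C2=CCC[C@](C)(C[C@H](O)c3ccoc3)[C@H]2CC[C@H]1C` is the one compound of the pair with a number, giving 66000 nM in this assay. Among the compounds with values here, the single measured step, an at least 1.5-fold lower number from compound 1 to compound 2 (0.18 log units; that floor lies within the scatter), rests on the limit of > 100000 nM in this assay, at which 1 of the 2 values shown sits, and so carries little weight. Compound 3 `C=C(C)CCC[C@]1(C)C2=CCC[C@](C)(C[C@@H](O)C3=CC(=O)OC3O)[C@H]2CC[C@H]1C` differs from compound 2 by a group of 9 heavy atoms (5 carbon, 4 oxygen; one five-membered non-aromatic ring with 1 hetero atom) in place of a group of 7 heavy atoms (5 carbon, 2 oxygen; one five-membered aromatic ring with 1 hetero atom), on a saturated chain carbon bound to a saturated ring carbon. Within the data shown here, no measured step touches this change, so no shift beyond the scatter is expected. Compound 3 is therefore estimated at 45000 nM in this assay, with a range of 12000 nM to 150000 nM. The expected step is a 1.5-fold lower number from compound 2 to compound 3 (0.17 log units; within the scatter).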

Compound 3, half-maximal inhibitory concentration: 3800 nM
Beside the measured number, compound 3's estimate is 12-fold (1.07 log units) above it; measured number below the stated range.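

At the saturated chain carbon bound to a saturated ring carbon, the non-aromatic five-membered ring group in place of (furan-3-yl)(hydroxy)methyl gives, in this assay, a 17-fold lower number from compound 2 to compound 3 (1.24 log units; beyond the scatter). Going by these compounds alone, this is the first step at this place to lie beyond the scatter, so the group carried here can change the reading substantially. The second step, an at least 26-fold lower number from compound 1 to compound 3 (1.42 log units; beyond the scatter), is also large, but it is only a floor set by a limit: the limit of > 100000 nM in this assay, at which 1 of the 3 values shown sits.

The compounds shown do not separate which part of the entering group carries the shift. They also leave open how an amine or a carboxylic acid at this place would read.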